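The source may report more compounds than this note shows. Statements on the series, on what has been measured and on what is new or still open speak of the compounds shown alone.

In a functional assay on LNCaP cells (Homo sapiens) for cytotoxicity, read by MTT assay, with a stated time of 72 h (a lower number here means a stronger inhibitor, a higher number a weaker inhibitor), compound 1 `CNCCCNc1c(C(=O)NCc2ccc(F)cc2)nc(Br)c2cccnc12` gives 8000 nM. For compound 2 `O=C(NCCCNc1c(C(=O)NCc2ccc(F)cc2)nc(Br)c2cccnc12)c1ccccc1` this assay reports only a limit, > 10000 nM. Compound 3 `O=C(NCc1ccc(F)cc1)c1nc(Br)c2cccnc2c1N1CCNCC1` gives 4500 nM in this assay, and it stands alongside compound 1, separated by a 1.8-fold lower number from compound 1 to compound 3 (0.25 log units; within the scatter), a step within the scatter. Compound 4 `CN(C)CCCNc1c(C(=O)NCc2ccc(F)cc2)nc(Br)c2cccnc12` differs from compound 3 by (3-(dimethylamino)propyl)amino in place of piperazin-1-yl on an aromatic carbon. Among the measured compounds shown here, two measured steps bear on this change: a 1.8-fold lower number from compound 1 to compound 3 (0.25 log units; within the scatter), where piperazin-1-yl replaced (3-(methylamino)propyl)amino, and an at least 1.2-fold higher number from compound 1 to compound 2 (0.09 log units; that floor lies within the scatter), where the amine nitrogen of such a chain carried benzoyl instead of methyl. Neither reached beyond the scatter, so compound 4 is expected to sit near compound 1 in this assay, without a step beyond the scatter. Compound 4 is estimated at 7000 nM, with a range from 3500 nM to 14000 nM. The expected step is a 1.6-fold higher number from compound 3 to compound 4 (0.19 log units; within the scatter).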

Compound 4, half-maximal inhibitory concentration: 8000 nM
Compound 4: the middle estimate sits 1.1-fold (0.06 log units) below what was measured; the measured number falls inside the stated range.
By their numbers in this assay, from the lowest: compounds 3, 1 and 4 (each within the scatter of the next). At a limit, above all of these: compound 2.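

In this assay, methyl in place of hydrogen on the amine nitrogen of the chain gives no change at the digits printed from compound 1 to compound 4 (within the scatter). (3-(dimethylamino)propyl)amino in place of piperazin-1-yl on an aromatic carbon, para to a bromo group, gives a 1.8-fold higher number from compound 3 to compound 4 (0.25 log units; within the scatter), so ring and chain are not told apart here. Dimethylamino in place of benzamido on a saturated chain carbon, three bonds along the chain from a nitrogen on an aromatic ring, gives an at least 1.2-fold lower number from compound 2 to compound 4 (0.09 log units; that floor lies within the scatter). Compound 2 stands only at a limit: the limit of > 10000 nM in this assay, at which 1 of the 4 values shown sits.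

As far as these compounds go, whether a morpholine, a carboxylic acid or a longer chain at this carbon would move the number beyond the scatter stays open.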